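The compounds below may be only part of what the source reports. "The series", "measured", "known", "first", "only" and "open" are said of these compounds alone.

Measured so far in an ADME assay (liver) for pharmacokinetics, with Liver microsome (Rattus norvegicus) as the target, using microsomes; on this read-out lower numbers stand for a shorter-lived compound and higher numbers for a longer-lived compound:
- compound 1, `CCOc1cc(NC(=O)C2(NC(=O)c3ccc4c(C5CCCC5)c(-c5ncc(Cl)cn5)n(C)c4c3)CCC2)ccc1/C=C/C(=O)OCOP(=O)(O)OC(C)(C)C`: 0.133 h
- compound 2, `CCCOC(=O)/C=C/c1ccc(NC(=O)C2(NC(=O)c3ccc4c(C5CCCC5)c(-c5ncc(Cl)cn5)n(C)c4c3)CCC2)cc1OCC`: 0.35 h
- compound 3, `CCOc1cc(NC(=O)C2(NC(=O)c3ccc4c(C5CCCC5)c(-c5ncc(Cl)cn5)n(C)c4c3)CCC2)ccc1/C=C/C(=O)OCC(C)C`: 1.42 h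

Compound 3 holds the highest number of the three. Its nearest neighbour is compound 2, reached by a 4.1-fold higher number from compound 2 to compound 3 (0.61 log units; beyond the scatter); the furthest is compound 1, reached by an 11-fold higher number from compound 1 to compound 3 (1.03 log units; beyond the scatter). Between the two lower compounds the step is a 2.6-fold higher number from compound 1 to compound 2 (0.42 log units; beyond the scatter).

All three measured steps fall at the same place, on a saturated chain carbon bound to an oxygen next to a carbonyl group, and compound 4, `CCCN(C)C(=O)COC(=O)/C=C/c1ccc(NC(=O)C2(NC(=O)c3ccc4c(C5CCCC5)c(-c5ncc(Cl)cn5)n(C)c4c3)CCC2)cc1OCC`, changes that place again: methyl(propyl)carbamoyl in place of isopropyl on a saturated chain carbon bound to an oxygen next to a carbonyl group. The measured steps show that the identity of the group at this position moves this assay over a wide span, and the three cases do not run in one direction with size alone, since compound 1 carries the largest group and the lowest number. The entering methyl(propyl)carbamoyl group brings a carbonyl and a nitrogen where compound 3 has only carbon, which is closer in kind to compound 1 than to compound 3. The expectation is therefore a modest drop, a 3.6-fold lower number from compound 3 to compound 4 (0.55 log units; beyond the scatter), landing nearer compound 2 than compound 3. For compound 4 the estimate is 0.4 h, with a range of 0.15 h to 1.1 h.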

Compound 4, half-life: 0.317 h
For compound 4 the middle estimate is 1.3-fold (0.10 log units) above the measured one; the range from low to high includes it.
By their numbers in this assay, from the lowest: compound 1; then compounds 4 and 2 (each within the scatter of the next); then compound 3.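

In this assay, on a saturated chain carbon bound to an oxygen next to a carbonyl group, replacing isopropyl with methyl(propyl)carbamoyl costs most of the advantage held by compound 3: a 4.5-fold lower number from compound 3 to compound 4 (0.65 log units; beyond the scatter). The same group set against ethyl gives a 1.1-fold lower number from compound 2 to compound 4 (0.04 log units; within the scatter), so compound 2 and compound 4 cannot be told apart here, although the two groups differ widely in heavy-atom count and only one of them holds a carbonyl and a nitrogen. Compound 4 still stands clear of the lowest member of the series, with a 2.4-fold higher number from compound 1 to compound 4 (0.38 log units; beyond the scatter), and the series now shows that isopropyl, smaller than methyl(propyl)carbamoyl but larger than ethyl, gives the highest number, so heavy-atom count does not order these four compounds.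

No available evidence bears on the cause of these steps. Going by these compounds, it remains open whether the amide carbonyl or the branching of the chain decides the outcome at this place, and whether dimethylcarbamoyl, a tert-butyl group or a longer unbranched chain such as n-butyl would sit with compound 3 or with compound 2 and compound 4.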